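From hydroxy to fluoro: compound 3 and compound 4

The source may hold more compounds than are shown below. What is called first, only, known or untested is meant among the compounds shown, and "the series" means these compounds.

In a functional assay on NCI-H460 cells (Homo sapiens) for inhibition (a lower number here means a stronger inhibitor of growth, a higher number a weaker inhibitor of growth), compound 1 (`COc1ccc(-n2cnnc2-c2cc(OC)c(OC)c(OC)c2)cc1`) gives 3390 nM while compound 2 (`COc1cc(-c2nncn2-c2ccc(N(C)C)cc2)cc(OC)c1OC`) gives 178 nM and compound 3 (`COc1ccc(-n2cnnc2-c2cc(OC)c(OC)c(OC)c2)cc1O`) gives 407 nM and so stands between them. Compound 4 (`COc1ccc(-n2cnnc2-c2cc(OC)c(OC)c(OC)c2)cc1F`) is not yet measured. It carries fluoro in place of hydroxy on an aromatic carbon, ortho to a methoxy group and meta to a large group (fluoro in place of hydroxy on an aromatic carbon).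

The measured step closest to this change is an 8.3-fold lower number from compound 1 to compound 3 (0.92 log units; beyond the scatter) and it is modest, with hydroxy in place of hydrogen on that same carbon. The large step of a 19-fold lower number from compound 1 to compound 2 (1.28 log units; beyond the scatter) and its dimethylamino in place of methoxy concern a different group, so it bears only indirectly. Going by the values given here, no fluoro compound has been measured, so how much of the gain seen with compound 3 would remain is open. With the hydroxy gone, a modest move to a higher number is expected, and the estimated change is a 2.9-fold higher number from compound 3 to compound 4 (0.47 log units; beyond the scatter) in this assay for this pair. Compound 4 is estimated at 1200 nM with an expected range from 350 nM to 4000 nM before any measurement.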

Compound 4, concentration for 50% growth inhibition: 3160 nM
Compound 4: middle estimate off by 2.6-fold (0.42 log units), on the low side; measured number inside the range.
By their numbers in this assay, from the lowest: compound 2; then compound 3; then compounds 4 and 1 (each within the scatter of the next).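

Replacing hydroxy with fluoro removes the gain that hydroxy brought: in this assay the change is large enough to stand beyond the scatter (a 7.8-fold higher number from compound 3 to compound 4 (0.89 log units; beyond the scatter)). Fluoro on this aromatic carbon cannot be told apart from hydrogen (a 1.1-fold lower number from compound 1 to compound 4 (0.03 log units; within the scatter)), so among these compounds the gain at this position is seen with hydroxy and not with fluoro. Nothing available here accounts for the difference between the two groups.

The compounds shown leave open whether an amine or a carboxylic acid on this same carbon would keep the gain seen with hydroxy or lose it as fluoro does. They also leave open whether hydroxy on this carbon would bring any gain in a compound that carries the dimethylamino group of compound 2.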